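The compounds below may be only part of what the source reports. "The series", "measured", "known", "first", "only" and "open" are said of these compounds alone.

Measured so far:
compound 1 `O=C(Nc1cccc(-c2oc3cc(-c4ccc(F)cc4)ccc3c(=O)c2O)c1)c1ccc(C(F)(F)F)cc1` — 32600 nM
compound 2 `COc1cccc(C(=O)Nc2cccc(-c3oc4cc(-c5ccc(F)cc5)ccc4c(=O)c3O)c2)c1` — 15300 nM
compound 3 `Cc1cccc(C(=O)Nc2cccc(-c3oc4cc(-c5ccc(F)cc5)ccc4c(=O)c3O)c2)c1` — 7850 nM

All three share the same core and differ only in the ring attached to the carbonyl carbon of the amide. In a functional assay on MCF7 cells (Homo sapiens) for antiproliferative activity, read by CCK-8 assay, with a stated time of 72 h (a lower number here means a stronger inhibitor, a higher number a weaker inhibitor), compound 3 gives 7850 nM, the lowest of the three numbers. Of its two neighbours, the step of a 1.9-fold lower number from compound 2 to compound 3 (0.29 log units; within the scatter) lies within the scatter, so compound 2 and compound 3 cannot be told apart on these numbers; the step of a 4.2-fold lower number from compound 1 to compound 3 (0.62 log units; beyond the scatter) is beyond the scatter and shows compound 3 clearly ahead of compound 1.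

The next compound, compound 4 `O=C(Nc1cccc(-c2oc3cc(-c4ccc(F)cc4)ccc3c(=O)c2O)c1)c1cccc(F)c1`, differs from compound 3 only by fluoro in place of methyl on an aromatic carbon. Among the measured compounds shown here, no measured compound carries fluoro on this ring, so the closest guide is the step of a 1.9-fold lower number from compound 2 to compound 3 (0.29 log units; within the scatter), where one small group replaced another on the same aromatic carbon and the number barely moved. The larger step of a 4.2-fold lower number from compound 1 to compound 3 (0.62 log units; beyond the scatter) involved a bigger group at a different position and bears less on this exchange. A change of no size beyond the scatter is therefore expected, a 1.1-fold higher number from compound 3 to compound 4 (0.06 log units; within the scatter). For compound 4 in this assay the estimate is 9000 nM, with a range from 3500 nM to 25000 nM.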

Compound 4, half-maximal inhibitory concentration: 5770 nM
Estimate against measurement, compound 4: 1.6-fold (0.19 log units) above; low and high end bracket the measured number.
By their numbers in this assay, from the lowest: compounds 4, 3 and 2 (each within the scatter of the next, the first and the last beyond it); then compound 1.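

In this assay, fluoro and methyl on this aromatic carbon cannot be told apart: the step of a 1.4-fold lower number from compound 3 to compound 4 (0.13 log units; within the scatter) lies within the scatter. Fluoro does separate from methoxy on the same carbon, with a 2.7-fold lower number from compound 2 to compound 4 (0.42 log units; beyond the scatter) as the first single-group exchange at this carbon to clear the scatter, which the methyl and methoxy pair did not do. The widest gap so far, a 5.6-fold lower number from compound 1 to compound 4 (0.75 log units; beyond the scatter), replaces the whole 3-fluorophenyl with 4-(trifluoromethyl)phenyl, so it cannot be pinned on one group alone.

Nothing here offers an explanation for these differences. On these data alone, it also remains open how chloro, hydroxy, an amine or a carboxylic acid on this same carbon would compare with fluoro, methyl and methoxy.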